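Oral exposure notes: from compound 2 to compound 3

This account rests on a few compounds, and the source may have more. Where it says the series, first, only, none or still open, it means among the compounds named here.

- compound 1 `NCCOc1ccc([C@H]2CC[C@]3(CC2)OOC2(O3)C3CC4CC(C3)CC2C4)cc1`: 287 nM
- compound 2 `c1cc([C@H]2CC[C@]3(CC2)OOC2(O3)C3CC4CC(C3)CC2C4)ccc1OCCC1CCNCC1`: 1190 nM

In an ADME assay on the whole organism (strain FVB) for pharmacokinetics, with Mus musculus as the target, read by LC-MS, at a dose of 30 mg/kg by the oral route (on this read-out higher numbers stand for higher exposure at the dose given and lower numbers for lower exposure), compound 2 has the higher of the two numbers at 1190 nM, and compound 1 stands at 287 nM. Compound 3 `CC(C)(CN)Oc1ccc([C@H]2CC[C@]3(CC2)OOC2(O3)C3CC4CC(C3)CC2C4)cc1` has not yet been measured. It differs from compound 2 as follows: 1-(aminomethyl)-1-methylethyl in place of 2-(piperidin-4-yl)ethyl on an oxygen on an aromatic ring. The entering group, unlike the one it replaces, has no ring.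

Among the compounds with values here, only one measured step bears on this change: a 4.1-fold higher number from compound 1 to compound 2 (0.62 log units; beyond the scatter). That step placed piperidin-4-yl where amino stood, and compound 3 again lacks that ring and has an open-chain amino group. A single step sets no rule, but a partial reversal of the step to compound 2 is expected, giving a lower number of similar or smaller size. The expected change is a 2.2-fold lower number from compound 2 to compound 3 (0.34 log units; beyond the scatter). Compound 3 is estimated at 550 nM, with an expected range of 180 nM to 1500 nM.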

Compound 3, maximal plasma concentration: 529 nM
Estimate against measurement, compound 3: 1.0-fold (0.02 log units) above, and the stated range covers the measured number.
By their numbers in this assay, from the lowest: compounds 1 and 3 (each within the scatter of the next); then compound 2.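

In this assay, placing 1-(aminomethyl)-1-methylethyl where 2-(piperidin-4-yl)ethyl stood on an oxygen on an aromatic ring gives a 2.2-fold lower number from compound 2 to compound 3 (0.35 log units; beyond the scatter), so this open-chain group does not keep the number reached with the ring. Against the other open-chain amine, the change from 2-aminoethyl gives a 1.8-fold higher number from compound 1 to compound 3 (0.27 log units; within the scatter), so these two groups are not separated here, and both stand lower than the piperidine of compound 2. No accompanying data bear on why the numbers differ.

Still open, from the compounds shown here alone, is whether the ring of compound 2 or the length of its chain goes with the higher number, which a 4-aminobutyl group at this oxygen would help separate. Also open, going by these compounds, is how a ring with a different hetero atom, such as morpholine or piperazine, would stand in this place.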